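The source may report more compounds than this note shows. Statements on the series, on what has been measured and on what is new or still open speak of the compounds shown alone.

Working notes on the series.

Three compounds have numbers in an assay for inhibition of Polyunsaturated fatty acid 5-lipoxygenase (Homo sapiens), read by spectrophotometry, tested at 10 uM; on this read-out higher numbers stand for more inhibition at the one concentration tested (going by the name of the read-out) and lower numbers for less inhibition. Compound 1, `O=C(c1ccccc1)c1sc(N2CCN(c3ccccc3)CC2)nc1-c1ccc([N+](=O)[O-])cc1`, gives 67.8% in this assay. Compound 2, `COc1ccc(-c2nc(N(c3ccccc3)c3ccccc3)sc2C(=O)c2ccccc2)cc1`, gives 92.8% in this assay. Compound 3, `CN(C(=S)NC(=O)c1ccccc1)c1ccccc1`, gives 78.7% in this assay. On these three numbers compound 3 stands second highest: its nearest neighbour is compound 1, whose number lies lower by a gap beyond the scatter, and the furthest is compound 2, whose number lies higher by a gap also beyond the scatter. For the measured compounds named here, no pair of these measured compounds differs in a single place, so no measured step exists for orientation.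

The next compound, compound 4, `O=C(NC(=S)N(c1ccccc1)c1ccccc1)c1ccccc1`, has not yet been measured in this assay. It differs from compound 3 in one place: phenyl in place of methyl on an amide-type nitrogen. The values of compound 2 and compound 3 both carry two phenyl groups on a nitrogen and are the two higher numbers, which is all that can be said of them.

The step from compound 3 to compound 4 in this assay is expected to be small and upward, a number 5.3 percentage points higher from compound 3 to compound 4 (within the scatter), at the edge of the scatter rather than clearly beyond it. Compound 4 is estimated at 84% in this assay, with a range from 66% to 96%.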

Compound 4, a percentage reported as inhibition, at one concentration (the size of the read-out at that concentration, not a potency): 73.3%
Beside the measured number, compound 4's estimate is 10.7 percentage points above it, within the range that was stated.
By their numbers in this assay, from the lowest: compounds 1, 4 and 3 (each within the scatter of the next, the first and the last beyond it); then compound 2.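

For the compounds shown here, one methyl-to-phenyl exchange now gives a first measured step: in this assay, replacing methyl with phenyl on the amide-type nitrogen whose other neighbours are an aromatic carbon and the thiocarbonyl carbon gives a number 5.4 percentage points lower from compound 3 to compound 4 (within the scatter) and so does not separate the two compounds. Going by these compounds alone, at this position, therefore, the larger group with its six-membered aromatic ring and the single-carbon methyl give readings that cannot be told apart, a finding the earlier compounds, with no pair differing in one place, could not provide. Nothing at hand bears on the reason for this outcome.

The compounds shown leave open whether this insensitivity extends to other groups on the same nitrogen, such as hydrogen, a longer chain like butyl, a benzyl group, or a chain ending in an amine or a carboxylic acid. Within the data shown here, they also leave open whether the same exchange would give a similar step on the other cores, and a single reading at one concentration gives no potency for either compound.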